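Plasma exposure notes: from compound 2 to compound 3

The source may report more compounds than this note shows. Statements on the series, on what has been measured and on what is new or still open speak of the compounds shown alone.

Compound 1 `O=C(Nc1ccc(F)c(-c2nc3ncc(-c4cc(F)cc(F)c4)cc3[nH]2)c1)N1CCCC1` and compound 2 `O=C(Nc1ccc(F)c(-c2nc3ncc(-c4ccc(O)cc4)cc3[nH]2)c1)N1CCCC1` share one core and differ in a single place. In an ADME assay on the whole organism (Mus musculus, strain Swiss Webster) for pharmacokinetics, read by LC-MS, at a dose of 50 mg/kg by the oral route (a lower number here means less compound in the circulation, a higher number more compound in the circulation at the dose given), compound 1 gives 4800 nM, while compound 2 gives 130 nM; the step of a 37-fold lower number from compound 1 to compound 2 (1.57 log units; beyond the scatter). Going by the values given here, compound 2 therefore stands lowest of the two numbers measured so far, with compound 1 as its only neighbour. Compound 3 `O=C(Nc1ccc(F)c(-c2nc3ncc(C(F)(F)F)cc3[nH]2)c1)N1CCCC1` is not yet measured; it differs from compound 2 by trifluoromethyl in place of 4-hydroxyphenyl on an aromatic carbon. Among the compounds with values here, the only measured step that bears on this change is a 37-fold lower number from compound 1 to compound 2 (1.57 log units; beyond the scatter), which touched the same place and was large. Within the data shown here, compound 3 carries neither the 4-hydroxyphenyl of compound 2 nor the 3,5-difluorophenyl of compound 1, so no measured step matches it directly. The expectation for compound 3 in this assay is a rise of about a 12-fold higher number from compound 2 to compound 3 (1.06 log units; beyond the scatter), since compound 2, which gives 130 nM, loses its 4-hydroxyphenyl. Compound 3 is estimated at 1500 nM, with a range of 400 nM to 6000 nM.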

Compound 3, maximal plasma concentration: 1080 nM
Compound 3: middle estimate off by 1.4-fold (0.14 log units), on the high side, and the stated range covers the measured number.
By their numbers in this assay, from the lowest: compound 2; then compound 3; then compound 1.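

In this assay the step of an 8.3-fold higher number from compound 2 to compound 3 (0.92 log units; beyond the scatter) shows that a group with no ring on this aromatic carbon can stand well above the 4-hydroxyphenyl, while the step of a 4.4-fold lower number from compound 1 to compound 3 (0.65 log units; beyond the scatter) leaves it below the 3,5-difluorophenyl. Compound 3 thus falls between two compounds that both carry a six-membered aromatic ring of carbon only, so the presence of such a ring at this place does not by itself set the order of the three numbers. The widest gap lies between the two ring-bearing compounds, compound 1 and compound 2, not between ring and no ring.

Open, on these data alone, is whether the low number of compound 2 goes with the hydroxyl or with the ring carrying it, which a plain phenyl or a 4-methoxyphenyl here would test. Also open, as far as these compounds go, is how an amine or a carboxylic acid on this carbon would read. No measurement at hand speaks to what lies behind these numbers.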